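The compounds below may be only part of what the source reports. "The series", "measured", "known", "first", "only" and "open" are said of these compounds alone.

Measured so far:
compound 1 `Fc1ccccc1-c1cn2ccnc2c(-c2ccc3ncn(C4CCCCC4)c3c2)n1`: 0.96%
compound 2 `CCc1ccc(-c2cn3ccnc3c(-c3ccc4ncn(Cc5ccccc5)c4c3)n2)cc1`: 19.1%

In a functional assay on DU-145 cells (Homo sapiens) for inhibition, read by sulforhodamine B assay, with a stated time of 48 h, tested at 10 uM (on this read-out higher numbers stand for more inhibition at the one concentration tested (going by the name of the read-out) and lower numbers for less inhibition), compound 2 gives 19.1%, the highest of the two numbers in hand. The nearest, compound 1, gives 0.96%, a number that sits lower by more than the usual scatter of repeated runs. Within the data shown here, compound 1 and compound 2 differ at more than one place, so no single-change step between measured compounds is available to calibrate against.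

Compound 3 `Cc1cccc(-c2cn3ccnc3c(-c3ccc4ncn(Cc5ccccc5)c4c3)n2)c1` has not yet been measured. It differs from compound 2 in one place: 3-methylphenyl in place of 4-ethylphenyl on an aromatic carbon. Among the measured compounds shown here, no measured pair isolates a change of this kind, so the direction of the step is open; the expectation is a small step, either none beyond the scatter or a modest fall from the level of compound 2. For compound 3 in this assay the estimate is 12%, with a range of 0% to 30%. This corresponds to an expected step of a number 7.1 percentage points lower from compound 2 to compound 3 (within the scatter).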

Compound 3, a percentage reported as inhibition, at one concentration (the size of the read-out at that concentration, not a potency): 14.2%
The estimate for compound 3 lay 2.2 percentage points below the measured number; the measured number falls inside the stated range.
By their numbers in this assay, from the lowest: compound 1; then compounds 3 and 2 (each within the scatter of the next).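

In this assay, 3-methylphenyl in place of 4-ethylphenyl on this aromatic carbon gives a number 4.9 percentage points lower from compound 2 to compound 3 (within the scatter), the first single-change step available in the series. This read-out therefore does not separate the two groups at this position, whose numbers are compound 2 at 19.1% and compound 3 at 14.2%. Swapping one of these carbon-only aryl groups for the other thus offers no clear handle on inhibition at the one concentration tested.

Open, going by these compounds, is whether a phenyl ring carrying an amine or a carboxylic acid, or a longer chain such as butyl, would shift the number at this position beyond the scatter, and whether the same swap reads alike with other groups elsewhere on the shared core. Nothing in hand gives a reason for the size of this step.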